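Working notes on the carbonyl side-chain series

The source may hold more compounds than are shown below. What is called first, only, known or untested is meant among the compounds shown, and "the series" means these compounds.

Compound 2 `Cc1cn(C2CC(N=[N+]=[N-])C(COC(=O)CCCC(=O)OC(C)(C)C)O2)c(=O)[nH]c1=O` carries a 3-(tert-butoxycarbonyl)propyl group on the carbonyl carbon. In a functional assay on MT4 cells (Homo sapiens) for cytotoxicity (a lower number here means that less compound is tolerated, a higher number that more compound is tolerated), compound 2 reaches only the limit > 50000 nM. Compound 1 `Cc1cn(C2CC(N=[N+]=[N-])C(COC(=O)OCCCCO)O2)c(=O)[nH]c1=O` likewise sits at the limit, giving > 50000 nM in this assay. The step that the two limits leave unreadable from compound 1 to compound 2 therefore cannot be read, both values resting on (the limit of > 50000 nM in this assay, at which 2 of the 2 values shown sit). Compound 3 `Cc1cn(C2CC(N=[N+]=[N-])C(COC(=O)OCCCO)O2)c(=O)[nH]c1=O` differs from compound 2 by 3-hydroxypropoxy in place of 3-(tert-butoxycarbonyl)propyl on a carbonyl carbon. No readable step bears on this change, both measured compounds sitting at the limit, so no step beyond the scatter is expected in this assay. The estimated step is a step that the limit leaves unreadable from compound 2 to compound 3. Compound 3 is therefore expected at 100000 nM, within 50000 nM to 300000 nM, most likely again reported as a limit.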

Compound 3, half-maximal cytotoxic concentration: > 50000 nM
Compound 3: a limit, no number (the forecaster's own chance of this, stated with the estimate: 85%); the middle value is on the limit's open side.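

Compound 3 joins compound 1 and compound 2 at the limit, so no step among these compounds can be read: the limit of > 50000 nM in this assay, at which 3 of the 3 values shown sit.

In this assay the compounds shown leave open the actual tolerated concentration of each one, and whether the side chains differ at all.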